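Three Flat Results Before a Second Fluorine

The source may hold more compounds than are shown below. What is called first, only, known or untested is meant among the compounds shown, and "the series" means these compounds.

Compound 1 `CC(C)(C)Cc1c(-c2ccncc2)sc(N)c1C(=O)c1ccc(Cl)cc1` is measured in an assay on CHO cells for displacement of a labelled ligand from adenosine receptor A1 (Homo sapiens), read by scintillation counting, tested at 10 uM (a higher number here means more inhibition at the concentration tested (going by the name of the read-out), a lower number less inhibition), where compound 1 gives 1%. In this assay compound 2 `CC(C)(C)Cc1c(-c2cccnc2)sc(N)c1C(=O)c1ccc(Cl)cc1` gives 1%, and compound 3 `CC(C)(C)Cc1c(-c2ccc(F)cc2)sc(N)c1C(=O)c1ccc(Cl)cc1` gives 1%. The steps between them tell one story: no change at the digits printed from compound 1 to compound 2 (within the scatter), no change at the digits printed from compound 1 to compound 3 (within the scatter) and no change at the digits printed from compound 2 to compound 3 (within the scatter). Compound 3 therefore stands level with compound 1 and compound 2 at the digits shown, all three showing essentially no displacement of the labelled ligand at the concentration tested.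

Compound 4 `CC(C)(C)Cc1c(-c2c(F)cccc2F)sc(N)c1C(=O)c1ccc(Cl)cc1` is not yet measured. It differs from compound 3 in one place: 2,6-difluorophenyl in place of 4-fluorophenyl on an aromatic carbon. All three measured steps exchange the group on this same aromatic carbon, and each left the read-out unchanged within the scatter, whether the group was pyridin-4-yl, pyridin-3-yl or 4-fluorophenyl. Nothing among these compounds suggests that placing 2,6-difluorophenyl there would lift the read-out, so the step expected is a number 1 percentage points higher from compound 3 to compound 4 (within the scatter), that is, no change beyond the scatter. Compound 4 is accordingly estimated to give 2% in this assay, within a range from -8% to 12%.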

Compound 4, a percentage reported as inhibition, at one concentration (the size of the read-out at that concentration, not a potency): 1%
Compound 4: middle estimate off by 1 percentage points, on the high side; the range from low to high includes it.
By their numbers in this assay, from the lowest: compounds 1, 2, 3 and 4 (each within the scatter of the next).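

Going from one fluorine to two, with 2,6-difluorophenyl in place of 4-fluorophenyl on the aromatic carbon next to the ring sulfur, gives no change at the digits printed from compound 3 to compound 4 (within the scatter) in this assay and so extends the flat result from swaps between aromatic rings to a change in the fluorine pattern on the phenyl ring itself. The comparisons with the two pyridine-bearing compounds read the same way, with no change at the digits printed from compound 2 to compound 4 (within the scatter) and no change at the digits printed from compound 1 to compound 4 (within the scatter) on the same measure, so this position has now held four different six-membered aromatic groups without any of them separating from the others. No measurement here offers an explanation for this flat pattern.

Every group shown at this position is a six-membered aromatic ring, so it remains open whether something of a different kind there, such as an amine, a carboxylic acid or a longer alkyl chain, would move the read-out at all. The neopentyl, amino and (4-chlorophenyl)carbonyl groups are the same in all four compounds, so what replacing any of them would do is also unknown.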